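Acetamide to methylurea on the shared core

A few compounds are considered here, and "the series" means these few. Any claim that something is new, unique, unknown or untested is made for them only; others in the source may bear on it.

Compound 2, `COc1ccc(-n2c(-c3ccc(NC(C)=O)cc3)nc3c2c(=O)n(C)c(=O)n3C)cc1F`: 1600 nM
Compound 1, `COC(=O)Nc1ccc(-c2nc3c(c(=O)n(C)c(=O)n3C)n2-c2ccc(OC)cc2)cc1`: 1700 nM

In a functional assay on T47D cells (Homo sapiens) for antiproliferative activity, read by MTT assay, with a stated time of 48 h (on this read-out higher numbers stand for weaker inhibition and lower numbers for stronger inhibition), compound 2 gives 1600 nM, and compound 1 gives 1700 nM, a gap within the scatter. Compound 3, `CNC(=O)Nc1ccc(-c2nc3c(c(=O)n(C)c(=O)n3C)n2-c2ccc(OC)c(F)c2)cc1`, has not yet been measured in this assay. It differs from compound 2 by methylamino in place of methyl on a carbonyl carbon. The two measured compounds share a similar carbonyl-bearing substituent and sit close together, so no step beyond the scatter is expected from this exchange. Compound 3 is therefore estimated at 1500 nM, between 600 nM and 4000 nM, which is expected to mean a step of a 1.1-fold lower number from compound 2 to compound 3 (0.03 log units; within the scatter).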

Compound 3, half-maximal inhibitory concentration: 4700 nM
Beside the measured number, compound 3's estimate is 3.1-fold (0.50 log units) below it, outside the stated range (above it).
By their numbers in this assay, from the lowest: compounds 2 and 1 (each within the scatter of the next); then compound 3.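

Exchanging 4-acetamidophenyl for 4-((methylcarbamoyl)amino)phenyl is not a neutral swap: this assay records a 2.9-fold higher number from compound 2 to compound 3 (0.47 log units; beyond the scatter), a modest weakening of inhibition. This is the first pair shown that differs in one place, so it is the first direct reading of methylamino in place of methyl on this carbonyl carbon. Nothing measured here accounts for the shift.

The compounds shown leave open how an ethylamino, a dimethylamino or a cyclopropyl group on the same carbonyl carbon would read. They also leave open whether the step holds on a core without the fluorine of compound 3.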